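A few compounds are considered here, and "the series" means these few. Any claim that something is new, unique, unknown or untested is made for them only; others in the source may bear on it.

Measured compounds:
- compound 1, `CCCOc1cccnc1-c1ccc(C(=O)Nc2ccc(C(C)(C)C)cc2)cc1`: 62 nM
- compound 2, `CCCNc1cccnc1-c1ccc(C(=O)Nc2ccc(C(C)(C)C)cc2)cc1`: 158 nM
- compound 3, `CC(C)(C)c1ccc(NC(=O)c2ccc(-c3ncccc3N(S(C)(=O)=O)S(C)(=O)=O)cc2)cc1`: 0.8 nM

Among these three, compound 3 stands lowest in a functional assay for antagonist activity at transient receptor potential cation channel subfamily V member 1 (Homo sapiens), read by FLIPR (on this read-out lower numbers stand for stronger inhibition and higher numbers for weaker inhibition), with 0.8 nM; the nearest of the others is compound 1, and the step of a 78-fold lower number from compound 1 to compound 3 (1.89 log units; beyond the scatter) ran the other way, while a 200-fold lower number from compound 2 to compound 3 (2.30 log units; beyond the scatter) was larger still. The step of a 2.5-fold higher number from compound 1 to compound 2 (0.41 log units; beyond the scatter) was modest by comparison.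

Compound 4, `CC(C)(C)c1ccc(NC(=O)c2ccc(-c3ncccc3-c3ncc[nH]3)cc2)cc1`, has not been measured. It differs from compound 3 in one place: 1H-imidazol-2-yl in place of bis(methylsulfonyl)amino on an aromatic carbon.

Among the measured compounds shown here, no measured step swaps the bis(methylsulfonyl)amino group for an aromatic ring, so none bears on this change directly. What the steps from compound 1 and compound 2 to compound 3 do show is that this group accounts for a large part of the low number of compound 3. Its removal is therefore expected to move the number up, and compound 4 is estimated to land at 20 nM, within 3 nM to 150 nM, a step of a 25-fold higher number from compound 3 to compound 4 (1.40 log units; beyond the scatter) that is expected to be clearly beyond the scatter.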

Compound 4, half-maximal inhibitory concentration: 3670 nM
Beside the measured number, compound 4's estimate is 180-fold (2.26 log units) below it; the measured number lies above the stated range.
By their numbers in this assay, from the lowest: compound 3; then compound 1; then compound 2; then compound 4.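

In this assay, among the compounds shown here, compound 4 has the highest number of the four compounds, and the step of a 4600-fold higher number from compound 3 to compound 4 (3.66 log units; beyond the scatter) is larger than any step among the earlier compounds. It also stands apart from the compounds with the smaller open-chain groups, with a 59-fold higher number from compound 1 to compound 4 (1.77 log units; beyond the scatter) and a 23-fold higher number from compound 2 to compound 4 (1.37 log units; beyond the scatter) as well, so at this position 1H-imidazol-2-yl does more than give up what bis(methylsulfonyl)amino contributes: it falls well past propoxy and propylamino too. Nothing at hand explains why this ring fares so poorly.

From the compounds shown here alone, it remains open whether a phenyl or pyridyl ring at this place, or a 1-methylimidazol-2-yl group, would behave in the same way. Going by these compounds, it is equally open whether a single methylsulfonylamino group would keep the low number of compound 3.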